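The source may report more compounds than this note shows. Statements on the series, on what has been measured and on what is new or still open speak of the compounds shown alone.

Compound 1 `COc1ccc(-c2nn(-c3ccc(S(N)(=O)=O)cc3)cc2C(CC(=O)c2ccc(Cl)cc2)C(=O)c2ccc(F)cc2)cc1`: 68.1%
Compound 2 `COc1ccc(C(=O)C(CC(=O)c2ccc(Cl)cc2)c2cn(-c3ccc(S(N)(=O)=O)cc3)nc2-c2ccc(OC)cc2)cc1`: 22.5%
Compound 3 `COc1ccc(-c2nn(-c3ccc(Cl)cc3)cc2-c2cc(-c3ccc(Cl)cc3)[nH]c2-c2ccc(F)cc2)cc1`: 61.9%

In a functional assay on the whole organism (strain Wistar albino) for inhibition, with Rattus norvegicus as the target, read by paw edema, with stated times of 1 h and 3 h, at a dose of 0.32 mmol/kg by the intraperitoneal route (on this read-out higher numbers stand for more inhibition at the one dose given (going by the name of the read-out) and lower numbers for less inhibition), compound 1 gives 68.1%, while compound 2 gives 22.5%. The change between them, (methoxy in place of fluoro on an aromatic carbon), made a step of a number 45.6 percentage points lower from compound 1 to compound 2 (beyond the scatter). Compound 3 gives 61.9% in this assay; how its core differs from the core of compound 1 is not broken down here. Compound 4 `COc1ccc(-c2nn(-c3ccc(Cl)cc3)cc2-c2cc(-c3ccc(Cl)cc3)[nH]c2-c2ccc(OC)cc2)cc1` has not yet been measured in this assay. It differs from compound 3 by methoxy in place of fluoro on an aromatic carbon, the same change that separates compound 1 from compound 2. Because compound 3 stands at 61.9% and the earlier step was a number 45.6 percentage points lower from compound 1 to compound 2 (beyond the scatter), a step of a number 31.9 percentage points lower from compound 3 to compound 4 (beyond the scatter) is expected. The two cores differ, which leaves the exact size open. Compound 4 is estimated at 30%, between 12% and 50%.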

Compound 4, a percentage reported as inhibition, in the whole organism at one dose (the size of the read-out at that dose, not a potency): 20.7%
For compound 4 the middle estimate is 9.3 percentage points above the measured one, within the range that was stated.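

Putting 4-methoxyphenyl in place of 4-fluorophenyl gave a number 41.2 percentage points lower from compound 3 to compound 4 (beyond the scatter) in this assay, so the loss of inhibition seen on the core of compound 1 carried over to the core of compound 3, with a similar size on both: the same change on two cores in this assay, a number 45.6 percentage points lower (beyond the scatter) from compound 1 to compound 2 and a number 41.2 percentage points lower (beyond the scatter) from compound 3 to compound 4, 4.4 percentage points apart, within the scatter of two such steps

This agreement rests on two pairs of compounds at a single dose. It does not show why methoxy lowers the inhibition, nor that the step would hold on a further core.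

The compounds shown carry only fluoro or methoxy at this place, so it remains open how an amine, a hydroxyl or a carboxylic acid there would read. From the compounds shown here alone, whether the step keeps its size at other doses also stays open.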